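The compounds below may be only part of what the source reports. "The series", "measured", "known", "first", "only" and "open" are said of these compounds alone.

Working notes on the series.

Compound 1 `CS(=O)(=O)c1ccc(C(=O)N2CCC(C(=O)N3CCN(c4ccc(F)cc4)CC3)CC2)cc1[N+](=O)[O-]` is the reference point. In an assay on isolated protein for inhibition of thyroid hormone receptor alpha (Homo sapiens), read by fluorescence polarization (on this read-out lower numbers stand for stronger inhibition and higher numbers for weaker inhibition), compound 1 returns > 60000 nM, which is a limit of the assay and not a number. Compound 2 `CS(=O)(=O)c1ccc(C(=O)NCCC(=O)N2CCc3ccccc32)cc1[N+](=O)[O-]` sits in the same position: in this assay compound 2 gives > 60000 nM, likewise a limit rather than a measured value. Within the data shown here, both values shown for the series therefore rest at the limit of > 60000 nM in this assay, at which 2 of the 2 values shown sit, and no step between measured compounds can be drawn from them.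

Compound 3 `CN1CCN(C(=O)C2CCN(C(=O)c3ccc(S(C)(=O)=O)c([N+](=O)[O-])c3)CC2)CC1` is not yet measured. It differs from compound 1 in one place: methyl in place of 4-fluorophenyl on an amine nitrogen in a ring. Among the measured compounds shown here, with no measured step to lean on, no direction for this change in this assay can be supported; the expectation is that the change stays within the scatter, or that the value again comes back as a limit.

For compound 3 in this assay the estimate is 80000 nM, with a range from 30000 nM to 300000 nM. The expected step from compound 1 to compound 3 is a step that the limit leaves unreadable from compound 1 to compound 3, meaning no change beyond the scatter is expected.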

Compound 3, half-maximal inhibitory concentration: > 60000 nM
Compound 3 ended at the assay's limit; the forecaster's own chance of this, stated with the estimate: 85%; the middle value is on the limit's open side.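

No new step can be read from compound 1 to compound 3, since both compounds stand at a limit of the assay and not at a number: the limit of > 60000 nM in this assay, at which 3 of the 3 values shown sit.

The compounds shown leave open whether any change to the shared core would bring a measured value within the range of this assay at all.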